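Methyl for methoxy on the anilide ring of compound 1

The compounds below may be only part of what the source reports. "The series", "measured", "known", "first", "only" and "open" are said of these compounds alone.

Compound 1 `COc1ccc(NC(=O)/C=C/C(=O)N2C/C(=C\c3ccc([N+](=O)[O-])cc3)C(=O)/C(=C/c3ccc([N+](=O)[O-])cc3)C2)cc1` is a bis-nitrobenzylidene piperidinone fumaramide; in a functional assay on L1210 cells (Mus musculus) for cytotoxicity (on this read-out higher numbers stand for weaker inhibition and lower numbers for stronger inhibition), compound 1 gives 2900 nM, the lower of the two numbers shown. Its companion compound 2 `COc1ccc(NC(=O)/C=C/C(=O)N2C/C(=C\c3ccccc3)C(=O)/C(=C/c3ccccc3)C2)cc1`, bearing unsubstituted benzylidene arms, gives 6800 nM in this assay, a gap beyond the scatter. Compound 3 `Cc1ccc(NC(=O)/C=C/C(=O)N2C/C(=C\c3ccc([N+](=O)[O-])cc3)C(=O)/C(=C/c3ccc([N+](=O)[O-])cc3)C2)cc1` differs from compound 1 only at the anilide end: methyl in place of methoxy on an aromatic carbon. Among the compounds with values here, with no measured pair of this kind to lean on, the step of a 1.0-fold higher number from compound 1 to compound 3 (0.01 log units; within the scatter) is expected to stay within the scatter, in no particular direction. Compound 3 is therefore estimated at 3000 nM, between 1200 nM and 7500 nM.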

Compound 3, half-maximal inhibitory concentration: 4400 nM
For compound 3 the middle estimate is 1.5-fold (0.17 log units) below the measured one; the range from low to high includes it.
By their numbers in this assay, from the lowest: compounds 1, 3 and 2 (each within the scatter of the next, the first and the last beyond it).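

Within the data shown here, the earlier compounds all carried methoxy at this position, so compound 3 gives the first reading of any other group there. In this assay, methyl in place of methoxy on the anilide ring gives a 1.5-fold higher number from compound 1 to compound 3 (0.18 log units; within the scatter), which shows that the methoxy oxygen can be removed here with no difference beyond the scatter. Nothing available explains this result.

Still open, going by these compounds, is whether an amine, a carboxylic acid or a longer alkoxy chain at this position would also stay within the scatter. Also open, on these data alone, is whether the same swap behaves alike with the unsubstituted benzylidene arms of compound 2.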